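Removing the aromatic methyl: notes toward compound 3

The source may hold more compounds than are shown below. What is called first, only, known or untested is meant among the compounds shown, and "the series" means these compounds.

Measured so far: compound 1 `Cc1cc(S(=O)(=O)NC(=O)c2ccc(N3CCN(Cc4ccccc4-c4ccc(Cl)cc4)CC3)cc2)ccc1N[C@H](CCN(C)C)CSc1ccccc1`, < 1 nM; compound 2 `CN(C)CC[C@H](CSc1ccccc1)Nc1ccc(S(=O)(=O)NC(=O)c2ccc(N3CCN(CC4=C(c5ccc(Cl)cc5)CCC4)CC3)cc2)cc1[N+](=O)[O-]`, < 1 nM.

In an assay on isolated protein for displacement of a labelled ligand from Bcl2-associated agonist of cell death (Homo sapiens), read by fluorescence polarization (on this read-out higher numbers stand for weaker inhibition and lower numbers for stronger inhibition), compound 1 gives < 1 nM, which is a limit of the assay rather than a measured number. Compound 2 gives < 1 nM in this assay, likewise a limit. Both compounds thus sit at the limit of < 1 nM in this assay, at which 2 of the 2 values shown sit, so no order between them can be drawn. Compound 3 `CN(C)CC[C@H](CSc1ccccc1)Nc1ccc(S(=O)(=O)NC(=O)c2ccc(N3CCN(Cc4ccccc4-c4ccc(Cl)cc4)CC3)cc2)cc1` differs from compound 1 by hydrogen in place of methyl on an aromatic carbon. For the measured compounds named here, no measured pair shows such a change; with the parent at the limit, a step no larger than the usual scatter is expected, a number no lower from compound 1 to compound 3 (the limit leaves the size open). Compound 3 is estimated at 1 nM, within 0.3 nM to 3 nM.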

Compound 3, inhibition constant: 14 nM
Estimate against measurement, compound 3: 14-fold (1.15 log units) below; the whole stated range lies below it.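

In this assay compound 1 gives < 1 nM, a limit and not a number. Hydrogen in place of methyl on this aromatic carbon, ortho to a large group and meta to a large group, gives an at least 14-fold higher number from compound 1 to compound 3 (1.14 log units; beyond the scatter), so the read-out is sensitive to the group at this position. Compound 3 is the only compound here with a number rather than a limit: the limit of < 1 nM in this assay, at which 2 of the 3 values shown sit.

From the compounds shown here alone, whether ethyl, methoxy or chlorine on this carbon would behave like methyl stays open. Going by these compounds, the full size of the step also stays open, as compound 1 is known only through its limit.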